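The source may hold more compounds than are shown below. What is called first, only, known or untested is meant among the compounds shown, and "the series" means these compounds.

compound 1 (`CN1C(=S)[C@@H](NC(=O)c2nc(Cc3ccccc3)n(C3CCCC3)n2)COc2ccccc21`) 3530 nM
compound 2 (`CN1C(=S)[C@@H](NC(=O)c2nc(Cc3ccccc3)n(C3CCOC3)n2)COc2ccccc21`) 1580 nM

Among the compounds with values here, in a functional assay on HT-29 cells (Homo sapiens) for inhibition, read by luminescence and CellTiter-Glo, with a stated time of 24 h (a lower number here means that less compound is needed, a higher number that more compound is needed for the effect), compound 2 at 1580 nM holds the lower of the two numbers so far, and compound 1 is its only neighbour. Compound 3 (`CN1C(=S)[C@@H](NC(=O)c2nc(Cc3ccccc3)n(CC3COC3)n2)COc2ccccc21`) shares the core of compound 2 and carries (oxetan-3-yl)methyl in place of oxolan-3-yl on an aromatic nitrogen. The two have the same atoms, joined differently. Within the data shown here, one measured step bears on this, at the same aromatic nitrogen: a 2.2-fold lower number from compound 1 to compound 2 (0.35 log units; beyond the scatter) for oxolan-3-yl in place of cyclopentyl. Among the measured compounds shown here, no measured compound carries (oxetan-3-yl)methyl, so the direction stays open, and no step beyond the scatter is expected in this assay for this smaller exchange. The expected result is a 1.1-fold higher number from compound 2 to compound 3 (0.06 log units; within the scatter) as estimated here. For compound 3 the estimated value is 1800 nM with an expected range from 700 nM to 4500 nM in this read-out.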

Compound 3, half-maximal effective concentration: 2830 nM
The estimate for compound 3 lay 1.6-fold (0.20 log units) below the measured number, within the range that was stated.
By their numbers in this assay, from the lowest: compounds 2, 3 and 1 (each within the scatter of the next, the first and the last beyond it).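

In this assay, the exchange at this aromatic nitrogen gives a 1.8-fold higher number from compound 2 to compound 3 (0.25 log units; within the scatter), and measured against the cyclopentyl group it gives a 1.2-fold lower number from compound 1 to compound 3 (0.10 log units; within the scatter). Compound 3 therefore cannot be told apart from either neighbour, although those two neighbours are separated by a step beyond the scatter. A ring oxygen in a group of this heavy-atom count is thus not enough by itself for a step beyond the scatter from cyclopentyl: oxolan-3-yl gives one, (oxetan-3-yl)methyl does not, and no measurement at hand accounts for this.

From the compounds shown here alone, whether an amine such as piperidin-4-yl, or a carboxylic acid on a longer chain, at this nitrogen would move the number beyond the scatter stays open. Also open, going by these compounds, is whether these small steps would persist with a group other than the benzyl group, which all three compounds share.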